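Changing a Distant Aryl Group: What Acid Dissociation Should Show

A few compounds are considered here, and "the series" means these few. Any claim that something is new, unique, unknown or untested is made for them only; others in the source may bear on it.

Three measured compounds share a common core. Compound 1 `FC(F)(F)c1ccc(-c2ccc3c(NCCCNCc4ccco4)ccnc3c2)cc1` gives 9.47 in a physicochemical assay for acid dissociation. Compound 2 `FC(F)(F)c1cc(-c2ccc3c(NCCCNCc4ccco4)ccnc3c2)cc(C(F)(F)F)c1` gives 9.47 in this assay, and compound 3 `COc1ccc(F)cc1CNCCCNc1ccnc2cc(-c3ccc(C(F)(F)F)cc3)ccc12` gives 9.47. Compound 1 therefore stands level with compounds 2 and 3 at the digits shown, inside the scatter of both. For the measured compounds named here, the single recorded step, no change at the digits printed from compound 1 to compound 3 (within the scatter), lies within the scatter, and compounds 1 and 2, which differ only in the aryl group on the core, show the same value.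

Compound 4 `N#Cc1ccc(Cc2ccc3c(NCCCNCc4ccco4)ccnc3c2)cc1` has not yet been measured. It differs from compound 1 in this way: 4-cyanobenzyl in place of 4-(trifluoromethyl)phenyl on an aromatic carbon. Going by the values given here, no measured step changes the core at exactly this place, but compounds 1 and 2 show that exchanging the aryl group there left the value unchanged, and no change at the digits printed from compound 1 to compound 3 (within the scatter) was equally flat. The expected step for compound 4 is therefore a number 0.02 log units lower from compound 1 to compound 4 (within the scatter), nothing beyond the scatter. Compound 4 is estimated to give 9.45 in this assay, between 9.15 and 9.75.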

Compound 4, acid dissociation constant: 9.47
Beside the measured number, compound 4's estimate is 0.02 log units below it; measured number inside the range.
By their numbers in this assay, from the lowest: compounds 1, 2, 3 and 4 (each within the scatter of the next).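

Swapping 4-(trifluoromethyl)phenyl for 4-cyanobenzyl on this aromatic carbon gives no change at the digits printed from compound 1 to compound 4 (within the scatter) in this assay and extends the flat picture to a different kind of substituent. Compounds 1 and 2 both carry trifluoromethyl groups on their aryl ring, whereas compound 4 has a benzyl group with a nitrile, no fluorine and one hydrogen-bond acceptor where the leaving group has none. This position therefore tolerates more than one kind of group without a visible shift in this read-out, though nothing available explains why the value holds.

Still open, as far as these compounds go, is whether a carboxylic acid or a primary amine on this same aromatic carbon would leave this assay just as flat. A longer chain between the aromatic ring and the core is equally untested by the compounds shown.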